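Vero cell tolerance across three aryl variants of one core

The source may report more compounds than this note shows. Statements on the series, on what has been measured and on what is new or still open speak of the compounds shown alone.

Measured so far:
- compound 1 `COc1nc(-c2ccc(C#N)cc2)ccc1[C@@H](c1ccccc1)[C@@](O)(CCN(C)C)c1cccc2ccccc12`: in a toxicity assay on Vero cells (Chlorocebus sabaeus) for cytotoxicity (a higher number here means that more compound is tolerated, a lower number that less compound is tolerated), compound 1 gives > 50 ug/mL, a limit of the assay rather than a number.
- compound 2 `COc1nc(-c2ccc(Cl)cc2)ccc1[C@@H](c1ccccc1)[C@@](O)(CCN(C)C)c1cccc2ccccc12`: compound 2 gives > 50 ug/mL, again a limit.
- compound 3 `COc1nc(-c2cccc(F)c2)ccc1[C@@H](c1ccccc1)[C@@](O)(CCN(C)C)c1cccc2ccccc12`: compound 3 gives > 50 ug/mL, also a limit.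

Within the data shown here, compound 3 thus stands where every value so far stands, at the limit of > 50 ug/mL in this assay, at which 3 of the 3 values shown sit. The three steps among the measured compounds, a step that the two limits leave unreadable from compound 1 to compound 2, a step that the two limits leave unreadable from compound 1 to compound 3 and a step that the two limits leave unreadable from compound 2 to compound 3, are all hidden by these limits, so none of them can be read for size or direction.

Compound 4 `COc1nc(-c2cnsc2)ccc1[C@@H](c1ccccc1)[C@@](O)(CCN(C)C)c1cccc2ccccc12` is the next member. Its change from compound 3 is 1,2-thiazol-4-yl in place of 3-fluorophenyl on an aromatic carbon. Among the measured compounds shown here, no measured step bears readably on this change; the only observation is that three different aryl groups at the same place all left the compounds tolerated up to the limit. No step beyond the scatter is expected for compound 4, and the value is likely to be reported as a limit again. Compound 4 is expected at 60 ug/mL, with a range from 35 ug/mL to 120 ug/mL, which means an expected step that the limit leaves unreadable from compound 3 to compound 4.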

Compound 4, half-maximal cytotoxic concentration: 26.3 ug/mL
Compound 4: middle estimate off by 2.3-fold (0.36 log units), on the high side; measured number outside the range, below it.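

With 1,2-thiazol-4-yl at this place, this assay yields the only actual number for the shared core, while the other compounds remain at a limit of the assay: the limit of > 50 ug/mL in this assay, at which 3 of the 4 values shown sit.

Replacing 3-fluorophenyl gives an at least 1.9-fold lower number from compound 3 to compound 4 (0.27 log units; that floor lies within the scatter), replacing 4-chlorophenyl gives an at least 1.9-fold lower number from compound 2 to compound 4 (0.27 log units; that floor lies within the scatter), and replacing 4-cyanophenyl gives an at least 1.9-fold lower number from compound 1 to compound 4 (0.27 log units; that floor lies within the scatter). Each of these is only a floor and lies within the scatter, so the change brings a value under the limit without establishing a step beyond the scatter, and the steps among compound 1, compound 2 and compound 3 cannot be read.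

Open, from the compounds shown here alone, is whether a thienyl or a pyridyl group at this place would also give a number under the limit. Open too, going by these compounds, is whether that outcome follows the five-membered ring or its hetero atoms.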